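The compounds below may be only part of what the source reports. "The series", "measured", "known", "first", "only" and "open" are said of these compounds alone.

The series shares one core carrying a saturated chain on an amide nitrogen. Compound 1 `CCCCCCCCCCCCNC(=O)[C@@H](NC(=O)c1cc2ccccc2o1)[C@@H](C)O` and compound 2 `CCCCCCCCCCCCCCNC(=O)[C@@H](NC(=O)c1cc2ccccc2o1)[C@@H](C)O` differ only in that chain; in a functional assay on SiHa cells (Homo sapiens) for cytotoxicity, read by MTT assay, with a stated time of 48 h (on this read-out lower numbers stand for stronger inhibition and higher numbers for weaker inhibition), compound 1 gives 12900 nM and compound 2 gives 14200 nM, and the step of a 1.1-fold higher number from compound 1 to compound 2 (0.04 log units; within the scatter) is small. Compound 3 `CCCCCCCCCCCCCCCCCCNC(=O)[C@@H](NC(=O)c1cc2ccccc2o1)[C@@H](C)O` carries the longest chain. In this assay compound 3 gives only a limit, > 200000 nM, as noted by the limit of > 200000 nM in this assay, at which 1 of the 3 values shown sits. The steps of an at least 15-fold higher number from compound 1 to compound 3 (1.19 log units; beyond the scatter) and an at least 14-fold higher number from compound 2 to compound 3 (1.14 log units; beyond the scatter) are therefore large, and compound 3 stands at the weak end of the measured set, beyond the scatter from both others.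

Compound 4 `CCCCCCCCCCCCCCCCCCNC(=O)[C@@H](NS(=O)(=O)c1cccs1)[C@@H](C)O` keeps the chain of compound 3 and alters the group on the amine nitrogen: (thiophen-2-yl)sulfonyl in place of (1-benzofuran-2-yl)carbonyl on an amine nitrogen. For the measured compounds named here, none of the measured steps touches this position; all three concern the chain only, so they give no direction for the step in this assay. With the starting point at the limit, compound 4 is expected to remain near it, the expected step being a number no higher from compound 3 to compound 4 (the limit leaves the size open). Compound 4 is thus estimated at 200000 nM, between 60000 nM and 600000 nM, with a real chance that only a limit is again reported.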

Compound 4, half-maximal inhibitory concentration: > 200000 nM
Compound 4 was reported as a limit; the forecaster's own chance of this, stated with the estimate: 60%; the middle value sits exactly at the limit.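

In this assay compound 4 gives only a limit, > 200000 nM, as compound 3 does, so no step between compound 3 and compound 4 can be read: the limit of > 200000 nM in this assay, at which 2 of the 4 values shown sit.

The compounds shown leave open how (thiophen-2-yl)sulfonyl in place of (1-benzofuran-2-yl)carbonyl on an amine nitrogen compares when a readable value is available on both sides.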